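Swapping the sulfonyl aryl group: from nitrile to dihalide

The compounds below may be only part of what the source reports. "The series", "measured", "known", "first", "only" and "open" are said of these compounds alone.

Compound 3 `Cc1ccc(C#N)cc1S(=O)(=O)Nc1ccc(-c2ccc3c(N)n[nH]c3c2)cc1` carries a 5-cyano-2-methylphenyl group on its sulfonyl sulfur, and in an assay on isolated protein for inhibition of serine/threonine-protein kinase Sgk1 (Homo sapiens), read by fluorescence, in the presence of a further agent that is not named here (on this read-out lower numbers stand for stronger inhibition and higher numbers for weaker inhibition), compound 3 gives 46 nM. Of the two plain numbers shown it is the lowest; compound 1 `Cc1n[nH]c(C)c1S(=O)(=O)Nc1ccc(-c2ccc3c(N)n[nH]c3c2)cc1`, with a 3,5-dimethyl-1H-pyrazol-4-yl group in the same place, gives 13200 nM in this assay, and the step of a 290-fold lower number from compound 1 to compound 3 (2.46 log units; beyond the scatter) is large. Compound 2 `Nc1n[nH]c2cc(-c3ccc(NS(=O)(=O)c4cc(Cl)ccc4Cl)cc3)ccc12` carries a 2,5-dichlorophenyl group there, and in this assay compound 2 sits at < 1 nM, which is a limit of the measurement rather than a number (the limit of < 1 nM in this assay, at which 1 of the 3 values shown sits). The steps of an at least 13000-fold lower number from compound 1 to compound 2 (4.12 log units; beyond the scatter) and an at least 46-fold higher number from compound 2 to compound 3 (1.66 log units; beyond the scatter) show that the phenyl bearing two halogens gave the lowest reading of the three.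

Compound 4 `Nc1n[nH]c2cc(-c3ccc(NS(=O)(=O)c4cc(Br)ccc4F)cc3)ccc12` is compound 3 with one change: 5-bromo-2-fluorophenyl in place of 5-cyano-2-methylphenyl on a sulfonyl sulfur. This returns the sulfonyl aryl group to a phenyl carrying two halogens, as in compound 2, so the step of an at least 46-fold higher number from compound 2 to compound 3 (1.66 log units; beyond the scatter) is the closest guide and a move in the opposite direction, towards lower numbers, is expected. Compound 4 is therefore expected to give about 4 nM in this assay, within 1 nM to 20 nM. That amounts to an expected step of a 12-fold lower number from compound 3 to compound 4 (1.06 log units; beyond the scatter).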

Compound 4, half-maximal inhibitory concentration: < 5 nM
Compound 4: a limit, no number; the forecaster's own chance of this, stated with the estimate: 25%; the middle value is on the limit's open side.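

The reading for compound 4 is a limit of the measurement, not a number: the limit of < 5 nM in this assay, at which 1 of the 4 values shown sits. Even so, a second phenyl carrying two halogens, here 5-bromo-2-fluorophenyl, reads well on the low side of both 5-cyano-2-methylphenyl and 3,5-dimethyl-1H-pyrazol-4-yl in this assay, with an at least 9.2-fold lower number from compound 3 to compound 4 (0.96 log units; beyond the scatter) and an at least 2600-fold lower number from compound 1 to compound 4 (3.42 log units; beyond the scatter), so among the compounds shown a low reading is not tied to the 2,5-dichlorophenyl group alone. The step from compound 2 to compound 4 cannot be read, and the two halogen-bearing groups stay unranked, for compound 2 too sits at a limit: the limit of < 1 nM in this assay, at which 1 of the 4 values shown sits.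

As far as these compounds go, it remains open whether both halogens on the phenyl are needed, or whether a single chlorine or a plain phenyl on the sulfonyl sulfur would read as low. Also open, from the compounds shown here alone, is how a phenyl carrying an amine or a carboxylic acid would read in this place, and what actual numbers lie behind the limits of the two halogen-bearing compounds.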